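This account rests on a few compounds, and the source may have more. Where it says the series, first, only, none or still open, it means among the compounds named here.

Compound 2 `CCOc1ccccc1-c1ccc(-c2nc3cnccc3c(N)c2C#N)cc1` stands highest of the three compounds measured in a physicochemical assay for lipophilicity, read by HPLC, at pH 7.5 (a higher number here means a more lipophilic compound, a lower number a more polar compound), where compound 2 gives 3. Compound 3 `CC[C@@H](Nc1c(C#N)c(-c2ccc(-c3ccccc3Cl)cc2)nc2cnccc12)C(N)=O` lies nearest, and in this assay compound 3 gives 2.9, within the scatter. Compound 1 `CC[C@@H](Nc1c(C#N)c(-c2ccc(-c3ccncc3C)cc2)nc2cnccc12)C(N)=O` lies furthest, and in this assay compound 1 gives 2, beyond the scatter. Compound 4 `CCOc1ccccc1-c1ccc(-c2nc3cnccc3c(N[C@H](CC(C)C)C(N)=O)c2C#N)cc1` differs from compound 2 in one place: 1-carbamoyl-3-methylbutyl in place of hydrogen on a nitrogen on an aromatic ring. Within the data shown here, the only measured step, a number 0.90 log units higher from compound 1 to compound 3 (beyond the scatter), concerns a change on an aromatic carbon, so no measured step bears directly on this change at the nitrogen. The entering group brings six carbons together with one hydrogen-bond donor and one acceptor, so only a small rise, at the edge of the scatter, is expected, a step of a number 0.30 log units higher from compound 2 to compound 4 (within the scatter). For compound 4 the estimate in this assay is 3.3, between 2.7 and 3.9.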

Compound 4, distribution coefficient: 3.4
Beside the measured number, compound 4's estimate is 0.10 log units below it; low and high end bracket the measured number.
By their numbers in this assay, from the lowest: compound 1; then compounds 3 and 2 (each within the scatter of the next); then compound 4.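

In this assay, among these compounds, 1-carbamoyl-3-methylbutyl in place of hydrogen on this nitrogen gives a number 0.40 log units higher from compound 2 to compound 4 (beyond the scatter), the first measured step at this place. The step is modest, but it shows that the number responds to a change on the nitrogen, which the earlier step, made on an aromatic carbon, could not show. Nothing available explains the size of this step. Among the compounds shown here, with only one step here, it remains open how a simple methyl on this nitrogen, or a carboxylic acid in place of the carbamoyl group, would read.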